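Clearance of a Hydroxymethyl-Piperidine Analogue of Compound 1

This account rests on a few compounds, and the source may have more. Where it says the series, first, only, none or still open, it means among the compounds named here.

Compound 1 `Fc1ccccc1Cn1nc(-c2ncc(F)c(OCC3CC3)n2)cc1-c1ccon1`: 450 uL/min
Compound 2 `Fc1ccccc1Cn1nc(-c2ncc(F)c(N3CCCCC3)n2)cc1-c1ccon1`: 490 uL/min

In an ADME assay on microsomes from liver (Rattus norvegicus) for pharmacokinetics (a lower number here means slower removal, a higher number faster removal of the compound), compound 1 gives 450 uL/min, the lowest of the two numbers measured, with compound 2 the nearest at 490 uL/min. The step of a 1.1-fold higher number from compound 1 to compound 2 (0.04 log units; within the scatter) does not separate the two beyond the scatter. Compound 3 `OCC1CCCCN1c1nc(-c2cc(-c3ccon3)n(Cc3ccccc3F)n2)ncc1F` is the unmeasured analogue; it differs from compound 1 in one place: 2-(hydroxymethyl)piperidin-1-yl in place of cyclopropylmethoxy on an aromatic carbon. Going by the values given here, the one measured step that bears on this change is a 1.1-fold higher number from compound 1 to compound 2 (0.04 log units; within the scatter), which exchanges the same cyclopropylmethoxy for a piperidin-1-yl lacking the hydroxymethyl, and it stayed within the scatter. Because a 1.1-fold higher number from compound 1 to compound 2 (0.04 log units; within the scatter) was so small, the expectation for compound 3 is a step of a 1.0-fold higher number from compound 1 to compound 3 (0.02 log units; within the scatter) in this assay, not beyond the scatter in either direction. Compound 3 is therefore estimated at 470 uL/min in this assay, with a range from 240 uL/min to 920 uL/min.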

Compound 3, intrinsic clearance in a liver preparation (reported as CLH), per the amount of preparation that the assay uses: 460 uL/min
Beside the measured number, compound 3's estimate is 1.0-fold (0.01 log units) above it; measured number inside the range.
By their numbers in this assay, from the lowest: compounds 1, 3 and 2 (each within the scatter of the next).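

In this assay, placing 2-(hydroxymethyl)piperidin-1-yl on the aromatic carbon next to the ring nitrogen and ortho to a fluoro group in place of cyclopropylmethoxy gives a 1.0-fold higher number from compound 1 to compound 3 (0.01 log units; within the scatter). Hydroxymethyl in place of hydrogen on the saturated ring carbon gives a 1.1-fold lower number from compound 2 to compound 3 (0.03 log units; within the scatter), so this added group, with its hydrogen-bond donor, leaves the clearance number within the scatter of the plain piperidine, and all three groups at this position read alike in this assay. Nothing given here accounts for this lack of separation.

The compounds shown leave open whether a carboxylic acid or a primary amine in place of the hydroxymethyl, or a longer hydroxyalkyl chain on the piperidine, would give a step beyond the scatter. They also leave open whether a change elsewhere on the core of compound 1, such as at the 2-fluorobenzyl group, would move the number.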